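This account rests on a few compounds, and the source may have more. Where it says the series, first, only, none or still open, it means among the compounds named here.

Compound 1 `Cc1ccc(-c2c(C)c(-c3ccc(C)c(C)c3)c(C(OC(C)(C)C)C(=O)O)c(C)c2NS(C)(=O)=O)cc1C` gives 15000 nM in an ADME assay on MT4 cells (Homo sapiens) for cytotoxicity, read by MTT assay, with a stated time of 4 days; a lower number here means that less compound is tolerated, a higher number that more compound is tolerated.
Compound 2 `Cc1ccc(-c2c(C)c(-c3ccc(C)c(C)c3)c(C(OC(C)(C)C)C(=O)O)c(C)c2N)cc1C` gives 12000 nM in this assay.
Compound 3 `Cc1ccc(-c2c(C)c(-c3ccc(C)c(C)c3)c(C(OC(C)(C)C)C(=O)O)c(C)c2NC(=O)Nc2ccccc2)cc1C` gives 8000 nM in this assay.

These three share one core and differ only in the group on a nitrogen on an aromatic ring. Compound 3 carries the lowest of the three numbers, but the steps that lead to it are small: a 1.9-fold lower number from compound 1 to compound 3 (0.27 log units; within the scatter) and a 1.5-fold lower number from compound 2 to compound 3 (0.18 log units; within the scatter), and between the other two, a 1.3-fold lower number from compound 1 to compound 2 (0.10 log units; within the scatter). None of these is large enough to set the compounds apart, so on these numbers compound 3 sits with the others rather than below them.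

Compound 4 `Cc1ccc(-c2c(C)c(-c3ccc(C)c(C)c3)c(C(OC(C)(C)C)C(=O)O)c(C)c2NS(=O)(=O)c2ccccc2)cc1C` has not yet been measured. It differs from compound 3 by phenylsulfonyl in place of phenylcarbamoyl on a nitrogen on an aromatic ring. The measured steps that bear on this are the exchanges at the same nitrogen: a methylsulfonyl group already appears in compound 1, and the step of a 1.9-fold lower number from compound 1 to compound 3 (0.27 log units; within the scatter) shows that exchanging it for phenylcarbamoyl changed little. Across the three measured compounds, hydrogen, methylsulfonyl and phenylcarbamoyl at this position all gave much the same reading. For compound 4 the expected step is therefore a 1.3-fold higher number from compound 3 to compound 4 (0.10 log units; within the scatter), within the scatter. Compound 4 is expected to give about 10000 nM in this assay, within a range from 4000 nM to 25000 nM.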

Compound 4, half-maximal cytotoxic concentration: 11000 nM
Compound 4: the middle estimate sits 1.1-fold (0.04 log units) below what was measured; the range from low to high includes it.
By their numbers in this assay, from the lowest: compounds 3, 4, 2 and 1 (each within the scatter of the next).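

Within the data shown here, for the first time, the group on the nitrogen keeps its phenyl ring while the link to that nitrogen changes from carbamoyl to sulfonyl, and this gives a 1.4-fold higher number from compound 3 to compound 4 (0.14 log units; within the scatter) in this assay. The sulfonyl link can also now be read on its own terms: phenyl in place of methyl on the sulfonyl sulfur gives a 1.4-fold lower number from compound 1 to compound 4 (0.13 log units; within the scatter), and phenylsulfonyl in place of hydrogen on the nitrogen gives a 1.1-fold lower number from compound 2 to compound 4 (0.04 log units; within the scatter), so neither the size of the group on the sulfonyl sulfur nor the presence of a sulfonyl group separates these compounds, and no measurement at hand bears on why these readings stay together.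

All four compounds share one core and vary only at this nitrogen, so nothing here tells whether the same flat picture would hold once the core itself is changed. As far as these compounds go, it also remains open how this assay would read with a longer alkyl chain on the sulfonyl sulfur, or with an amine or a fluorine atom on the phenyl ring of the phenylsulfonyl group.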